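From Phenyl to Ethyl: an Untested Analogue

The source may report more compounds than this note shows. Statements on the series, on what has been measured and on what is new or still open speak of the compounds shown alone.

Measured compounds:
compound 1, `Cc1cc(C)n(-c2ccc(S(=O)(=O)NC(=O)NNC(=N)N)cc2)n1`, 3%;
compound 2, `Cc1cc(C)n(-c2ccc(S(=O)(=O)NC(=S)NCc3ccccc3)cc2)n1`, 0%.

Both were tested in a functional assay on the whole organism (blood, strain albino) with Mus musculus as the target, with stated times of 6 days and 4 h, at a dose of 0.4 mmol/kg by the oral route; a lower number here means less inhibition, a higher number more inhibition at the dose given (going by the name of the read-out). Compound 1 gives 3%, and compound 2 gives 0%. Compound 2 holds the lower of the two numbers, but compound 1 lies close by, within the usual scatter, so the two cannot be ordered.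

Compound 3, `CCCNC(=S)NS(=O)(=O)c1ccc(-n2nc(C)cc2C)cc1`, has not yet been measured in this assay. It differs from compound 2 in a single place: ethyl in place of phenyl on a saturated chain carbon bound to an amide-type nitrogen.

Going by the values given here, no step between two measured compounds is available, so the weight of this change is unknown. Because compound 2 already shows 0%, and compound 1 sits in the same region, no step beyond the scatter is expected in this assay in either direction. Compound 3 is expected to give about 2%, within -6% to 12%. The estimated step of a number 2 percentage points higher from compound 2 to compound 3 (within the scatter) amounts to nothing beyond the scatter.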

Compound 3, a percentage reported as inhibition, in the whole organism at one dose (the size of the read-out at that dose, not a potency): < 1%
Compound 3: only a limit was reported; the forecaster's own chance of this, stated with the estimate: 0%; middle value at least 1 percentage points from the limit.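

In this assay, compound 3 gives < 1%, which is a limit and not a number. Ethyl in place of phenyl on a saturated chain carbon bound to an amide-type nitrogen therefore brings no readable inhibition at the dose given, and the size of this step cannot be read: the limit of < 1% in this assay, at which 1 of the 3 values shown sits. On the sulfonamide nitrogen, the exchange of the whole group gives a number at least 2 percentage points lower from compound 1 to compound 3 (that floor lies within the scatter), so this comparison does not set the two compounds apart either.

The compounds shown leave open whether any group at this place, such as an amine or a carboxylic acid, would give a reading clear of the scatter. With all three results this close to nothing, they also cannot tell which parts of the shared core matter for inhibition in this assay.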